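This account rests on a few compounds, and the source may have more. Where it says the series, first, only, none or still open, it means among the compounds named here.

Of the compounds shown here, three sharing one core have been measured for how much of each is needed to switch on the receptor. In an in vitro functional assay on cells for agonist activity at Bombesin receptor subtype-3 (Homo sapiens), read by luminescence and calcium flux (on this read-out higher numbers stand for an effect only at larger amounts of compound and lower numbers for an effect already at smaller amounts), compound 1 `O=C(O)c1ccccc1-c1ccc(CCc2ncc(CCC3CCCCC3)[nH]2)cc1` gives 642 nM. Compound 2 `Cc1cccc(Cc2cnc(CCc3ccc(-c4ccccc4C(=O)O)cc3)[nH]2)c1` gives 4310 nM, and compound 3 `CC(C)(C)CCc1cnc(CCc2ccc(-c3ccccc3C(=O)O)cc2)[nH]1` gives 39 nM. On these numbers compound 1 stands second highest of three: it sits a 6.7-fold higher number from compound 1 to compound 2 (0.83 log units; beyond the scatter) and a 16-fold lower number from compound 1 to compound 3 (1.22 log units; beyond the scatter).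

Compound 4 `CC(C)(C)c1cnc(CCc2ccc(-c3ccccc3C(=O)O)cc2)[nH]1` is the next member, not yet measured. It differs from compound 1 in one place: tert-butyl in place of 2-cyclohexylethyl on an aromatic carbon.

Among the compounds with values here, only one measured step bears on this change directly. Replacing the cyclohexyl by tert-butyl gave a 16-fold lower number from compound 1 to compound 3 (1.22 log units; beyond the scatter), and moving from 3-methylphenyl to neopentyl gave a 110-fold lower number from compound 2 to compound 3 (2.04 log units; beyond the scatter), so a compact saturated group on that side of the core has so far gone with lower numbers. Compound 4 keeps tert-butyl but without the two-carbon chain, a shortening for which no step is shown. An improvement over compound 1 is therefore expected, but a smaller one than for compound 3, so the estimate for compound 4 is 250 nM, with a range of 50 nM to 1500 nM, meaning an expected step of a 2.6-fold lower number from compound 1 to compound 4 (0.41 log units; beyond the scatter).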

Compound 4, half-maximal effective concentration: 4330 nM
Estimate against measurement, compound 4: 17-fold (1.24 log units) below; the whole stated range lies below it.
By their numbers in this assay, from the lowest: compound 3; then compound 1; then compounds 2 and 4 (each within the scatter of the next).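

In this assay, tert-butyl placed directly on the aromatic carbon does not bring what the same group brought at the end of a chain: replacing 3,3-dimethylbutyl gives a 110-fold higher number from compound 3 to compound 4 (2.05 log units; beyond the scatter), so the chain counts here, not only the branched end. Replacing 2-cyclohexylethyl gives a 6.7-fold higher number from compound 1 to compound 4 (0.83 log units; beyond the scatter), which makes compound 4 an exception to the earlier link between compact saturated groups and lower numbers. Replacing 3-methylbenzyl gives a 1.0-fold higher number from compound 2 to compound 4 (0.00 log units; within the scatter), so these two very different groups cannot be told apart at this position in this assay.

Nothing available explains why removing the chain has so large an effect. Open, on these data alone, is how the numbers change with neopentyl on this same aromatic carbon, with a longer chain ending in tert-butyl, or with an amine at the end of the chain.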